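Ethoxy in place of trifluoromethoxy on a thiazoloquinone anilide

The source may report more compounds than this note shows. Statements on the series, on what has been measured and on what is new or still open speak of the compounds shown alone.

In a functional assay on HepG2 cells (Homo sapiens) for cytotoxicity, read by MTT assay (a lower number here means a stronger inhibitor, a higher number a weaker inhibitor), the shared core of compound 1 `COC1=CC(=O)c2ncsc2C1=O` stands as "not tested" (no result reported). Two anilino derivatives of it were tested. In this assay compound 2 `Cc1nc2c(s1)C(=O)C=C(Nc1ccc(OC(F)(F)F)cc1)C2=O` reaches only the limit of the assay, > 100 ug/mL, so no single number is known for it. Compound 3 `Cc1nc2c(s1)C(=O)C=C(Nc1cccc(Br)c1)C2=O`, which carries a bromine on the anilino ring instead, gives 15 ug/mL in this assay. Among the three compounds shown, compound 2 is therefore the one that sits at the limit of > 100 ug/mL in this assay, at which 1 of the 3 values shown sits, while compound 3 is the only one with a measured number.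

Compound 4 `CCOc1ccc(NC2=CC(=O)c3sc(C)nc3C2=O)cc1` differs from compound 2 by one change: ethyl in place of trifluoromethyl on an oxygen on an aromatic ring. Among the compounds with values here, no measured pair shows what this particular exchange does in this assay, so the expectation rests on little. Compound 4 is expected to give 50 ug/mL in this assay, with a range from 15 ug/mL to 100 ug/mL. The step this implies, an at least 2.0-fold lower number from compound 2 to compound 4 (0.30 log units; that floor lies within the scatter), is expected to move toward stronger inhibition, though it could also fall back at the limit.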

Compound 4, half-maximal inhibitory concentration: 4.9 ug/mL
Compound 4: middle estimate off by 10-fold (1.01 log units), on the high side; the measured number lies below the stated range.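

In this assay, ethyl in place of trifluoromethyl on an oxygen on an aromatic ring gives an at least 20-fold lower number from compound 2 to compound 4 (1.30 log units; beyond the scatter), so this single exchange is enough to turn a compound with no measurable number into one with a clear value. The true size of the step may be larger still, since it starts from a limit of the assay and not from a number: the limit of > 100 ug/mL in this assay, at which 1 of the 4 values shown sits. This position on the anilino ring therefore matters strongly in this assay, which compound 3 could not show, as it differs from compound 4 in more than one place.

As far as these compounds go, whether a methoxy or a longer chain such as propoxy on the same oxygen would behave like the ethoxy of compound 4 remains open. So does the outcome with a hydroxyl or an amine in place of the ethoxy.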